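The compounds below may be only part of what the source reports. "The series", "measured", "known", "first", "only" and "open" are said of these compounds alone.

Measured compounds in a physicochemical assay for solubility, in phosphate buffer, at pH 7.4; a lower number here means a less soluble compound, a higher number a more soluble compound:
- compound 1, `CCOC(=O)c1c(-c2cccc([N+](=O)[O-])c2)[nH]c2cccc(OC)c2c1=O`, gives 49000 nM
- compound 2, `CCOC(=O)c1c(-c2ccc(Cl)c(Cl)c2)[nH]c2cccc(OC)c2c1=O`, gives 39000 nM
- compound 3, `CCOC(=O)c1c(-c2ccccc2)[nH]c2cccc(OC)c2c1=O`, reaches only a limit of the assay, > 100000 nM

Compound 3 therefore has no exact number in this assay; its value is known only as a limit, (the limit of > 100000 nM in this assay, at which 1 of the 3 values shown sits), and it stands at or beyond the top of the three values shown. Compound 1 and compound 2 lie close together: a 1.3-fold lower number from compound 1 to compound 2 (0.10 log units; within the scatter). Both sit below the limit of compound 3, with an at least 2.0-fold higher number from compound 1 to compound 3 (0.30 log units; that floor lies within the scatter) and an at least 2.5-fold higher number from compound 2 to compound 3 (0.40 log units; beyond the scatter).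

Compound 4, `CCOC(=O)c1c(-c2cccc(C)c2)[nH]c2cccc(OC)c2c1=O`, differs from compound 3 in one place: methyl in place of hydrogen on an aromatic carbon. For the measured compounds named here, the steps that bear on this change are those in which a group on the phenyl ring was removed, compound 1 to compound 3 and compound 2 to compound 3; both raised the number at least modestly, though in each case the end point is a limit. Adding a methyl group reverses the direction of those steps, so a somewhat lower number than the limit of compound 3 is expected, though a methyl group is smaller than the groups removed in those steps. The step from compound 3 to compound 4 is estimated at an at least 1.4-fold lower number from compound 3 to compound 4 (0.15 log units; that floor lies within the scatter). Compound 4 is expected to give about 70000 nM, within a range from 30000 nM to 150000 nM.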

Compound 4, solubility: > 100000 nM
Compound 4 gave a limit, no number; the forecaster's own chance of this, stated with the estimate: 35%; at least 1.4-fold (0.15 log units) between middle value and limit.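

In this assay compound 4 gives > 100000 nM, which is a limit of the assay and not a number. The step between compound 3 and compound 4 cannot be read, because both stand at a limit and neither has a number: the limit of > 100000 nM in this assay, at which 2 of the 4 values shown sit. What the result adds is that a substituted phenyl can stay at this limit, so a group on an aromatic carbon, meta to a large group, does not by itself bring the compound down to the numbers seen for the nitro group of compound 1 and the two chlorines of compound 2, with an at least 2.5-fold higher number from compound 2 to compound 4 (0.40 log units; beyond the scatter) and an at least 2.0-fold higher number from compound 1 to compound 4 (0.30 log units; that floor lies within the scatter); only the first of these floors lies clear of the scatter, so the gap to the 3,4-dichlorophenyl is the firmer of the two.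

Going by these compounds, how far compound 3 and compound 4 lie beyond the limit stays unknown, and with it any real effect of the methyl group in this assay. Also open, on these data alone, is whether a methoxy group, an amine or a carboxylic acid on the same carbon would stay at the limit or give a number, and whether a single chlorine would do so.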